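A few compounds are considered here, and "the series" means these few. Any claim that something is new, unique, unknown or untested is made for them only; others in the source may bear on it.

Three compounds have been measured in a functional assay on MCF7 cells (Homo sapiens) for antiproliferative activity, read by MTT assay, with a stated time of 72 h; a lower number here means a stronger inhibitor, a higher number a weaker inhibitor:

compound 1 `CC/C=C/C(=O)Nc1cc2c(N3CCc4ccccc43)ncnc2cc1OC` gives 4030 nM
compound 2 `CC/C=C/C(=O)Nc1cc2c(N3CCc4ccccc43)ncnc2cc1O[C@@H]1CCOC1` gives 8840 nM
compound 3 `COc1cc2ncnc(N3CCCc4ccccc43)c2cc1NC(=O)/C=C/CN(C)C` gives 1770 nM

Compound 1 and compound 2 differ in one place, (oxolan-3-yl in place of methyl on an oxygen on an aromatic ring), and that change gave a 2.2-fold higher number from compound 1 to compound 2 (0.34 log units; beyond the scatter). Compound 3 stands lowest of the three measured numbers, and its distance from compound 1 lies beyond the usual scatter. Compound 3 and compound 1 differ in more than one place, and the difference between the two cores is not broken down here.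

Compound 4 `CN(C)C/C=C/C(=O)Nc1cc2c(N3CCCc4ccccc43)ncnc2cc1O[C@@H]1CCOC1` has not yet been measured. It arises from compound 3 by oxolan-3-yl in place of methyl on an oxygen on an aromatic ring, at a place described in exactly the same words as for the earlier pair, so this is the same change, seen for the second time among these compounds. Among the compounds with values here, the step from compound 3 to compound 4 in this assay is expected to be a 2.2-fold higher number from compound 3 to compound 4 (0.34 log units; beyond the scatter), because a 2.2-fold higher number from compound 1 to compound 2 (0.34 log units; beyond the scatter) is the only earlier reading of this change and nothing here suggests the new core should respond differently. A single precedent is a thin basis, so the range is kept wide. Compound 4 is estimated at 3900 nM, with a likely span from 1800 nM to 8500 nM.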

Compound 4, half-maximal inhibitory concentration: 2850 nM
Beside the measured number, compound 4's estimate is 1.4-fold (0.14 log units) above it; measured number inside the range.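

In this assay, putting oxolan-3-yl in place of methyl on the oxygen on the aromatic ring gives a 1.6-fold higher number from compound 3 to compound 4 (0.21 log units; within the scatter). Set beside the earlier reading of the same change, the two steps cannot be told apart, so within these few numbers the change reads alike on both cores: the same change on two cores in this assay, a 2.2-fold higher number (0.34 log units; beyond the scatter) from compound 1 to compound 2 and a 1.6-fold higher number (0.21 log units; within the scatter) from compound 3 to compound 4, 1.4-fold (0.13 log units) apart, within the scatter of two such steps

This does not show that the change acts the same way on every core in the series, since it rests on just two pairs and the step on the core of compound 3 cannot, taken alone, be told from the scatter of repeated measurements.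

The compounds shown leave open how other groups on that oxygen, such as an ethyl group, a longer chain or a chain ending in an amine, would read in this assay. They also leave open whether the mirror-image form of the oxolan-3-yl group would give the same step.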